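This account rests on a few compounds, and the source may have more. Where it says the series, first, only, none or still open, it means among the compounds named here.

Measured in a physicochemical assay for solubility, at pH 7; on this read-out lower numbers stand for lower solubility and higher numbers for higher solubility:
- Compound 1 `CN1CCN(c2ccc(C(=O)Nc3n[nH]c4cc(C(=O)NC(C)(C)c5ccccc5)sc34)cc2)CC1`: 2000 nM
- Compound 2 `CCNC(=O)c1cc2[nH]nc(NC(=O)c3ccc(N4CCN(C)CC4)cc3)c2s1`: 67000 nM
- Compound 3 `CN1CCN(c2ccc(C(=O)Nc3n[nH]c4cc(C(=O)NC5CCc6ccccc65)sc34)cc2)CC1`: < 1000 nM, a limit of the assay

Compound 3 has no number on this scale, only (the limit of < 1000 nM in this assay, at which 1 of the 3 values shown sits). Compound 4 `CN1CCN(c2ccc(C(=O)Nc3n[nH]c4cc(C(=O)NCc5ccccc5)sc34)cc2)CC1` differs from it by one change: benzyl in place of 2,3-dihydro-1H-inden-1-yl on an amide-type nitrogen. Within the data shown here, three measured steps bear on this. The step of an at least 2.0-fold lower number from compound 1 to compound 3 (0.30 log units; that floor lies within the scatter) joins two groups that each carry a six-membered aromatic ring, while a 34-fold higher number from compound 1 to compound 2 (1.53 log units; beyond the scatter) and an at least 67-fold lower number from compound 2 to compound 3 (1.82 log units; beyond the scatter) are both large and involve ethyl, which has no ring. Benzyl keeps such a ring, so, going by an at least 2.0-fold lower number from compound 1 to compound 3 (0.30 log units; that floor lies within the scatter), no step beyond the scatter is expected in this assay. The estimate corresponds to an expected at least 1.5-fold higher number from compound 3 to compound 4 (0.17 log units; that floor lies within the scatter). Compound 4 is estimated at 1500 nM, with an expected range of 600 nM to 5000 nM.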

Compound 4, solubility: 8000 nM
Compound 4: middle estimate off by 5.3-fold (0.73 log units), on the low side; the whole stated range lies below it.
By their numbers in this assay, from the lowest: compound 1; then compound 4; then compound 2. At a limit, below all of these: compound 3.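

In this assay, keeping a six-membered aromatic ring on the amide-type nitrogen does not hold the read-out level: benzyl gives an at least 8.0-fold higher number from compound 3 to compound 4 (0.90 log units; beyond the scatter) and a 4.0-fold higher number from compound 1 to compound 4 (0.60 log units; beyond the scatter). Benzyl still falls short of ethyl, with an 8.4-fold lower number from compound 2 to compound 4 (0.92 log units; beyond the scatter). Compound 3 stands at a limit, so the first of these steps is only a floor: the limit of < 1000 nM in this assay, at which 1 of the 4 values shown sits.

What the compounds shown leave open is how phenethyl, a longer chain, would read on this nitrogen. Also open, as far as these compounds go, is what an amine or a carboxylic acid on the benzyl ring would do.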